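A few compounds are considered here, and "the series" means these few. Any claim that something is new, unique, unknown or untested is made for them only; others in the source may bear on it.

Measured so far in a functional assay on HeLa cells (Homo sapiens) for antiproliferative activity, read by MTT assay, with a stated time of 72 h; on this read-out higher numbers stand for weaker inhibition and lower numbers for stronger inhibition:
- Compound 1 `COc1cc(-n2ncnc2-c2ccc(C)cc2)cc(OC)c1OC`: 250 nM
- Compound 2 `COc1ccc(-c2ncnn2-c2cc(OC)c(OC)c(OC)c2)cc1`: 280 nM
- Compound 3 `COc1cc(-n2ncnc2-c2ccc(Cl)c(Cl)c2)cc(OC)c1OC`: > 10000 nM

The entry for compound 3 is a limit of the assay, not a number: > 10000 nM.

Compound 4 `COc1ccccc1-c1ncnn1-c1cc(OC)c(OC)c(OC)c1` has not been measured. It carries 2-methoxyphenyl in place of 3,4-dichlorophenyl on an aromatic carbon.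

Among the compounds with values here, two measured steps bear on this change: an at least 40-fold higher number from compound 1 to compound 3 (1.60 log units; beyond the scatter) and an at least 35-fold higher number from compound 2 to compound 3 (1.55 log units; beyond the scatter). Both were large, and both ended at 3,4-dichlorophenyl, so removing that group should bring a large move towards lower numbers. Within the data shown here, the third step, a 1.1-fold higher number from compound 1 to compound 2 (0.05 log units; within the scatter), suggests some tolerance in the group at this place, but no measured compound carries 2-methoxyphenyl.

The expected step is an at least 12-fold lower number from compound 3 to compound 4 (1.09 log units; beyond the scatter), towards stronger inhibition.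

For compound 4 the estimated value in this assay is 800 nM, with an expected range of 120 nM to 6000 nM.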

Compound 4, half-maximal inhibitory concentration: > 10000 nM
Compound 4: no number, only a limit (the forecaster's own chance of this, stated with the estimate: 15%); middle value at least 12-fold (1.09 log units) from the limit.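

In this assay compound 4 gives > 10000 nM, which is a limit of the assay and not a number. Placing 2-methoxyphenyl at this position in place of 4-methoxyphenyl gives an at least 35-fold higher number from compound 2 to compound 4 (1.55 log units; beyond the scatter), and placing it there in place of 4-methylphenyl gives an at least 40-fold higher number from compound 1 to compound 4 (1.60 log units; beyond the scatter). The loss of activity is therefore not confined to 3,4-dichlorophenyl, and the tolerance seen with compound 1 and compound 2 does not reach every substituted phenyl group.

From the compounds shown here alone, the step between compound 3 and compound 4 cannot be read, because both sit at one limit: the limit of > 10000 nM in this assay, at which 2 of the 4 values shown sit. Whether an amine or a hydroxyl group at this place would keep the activity stays open.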